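Cytotoxicity of three measured compounds and an estimate for a fourth

A few compounds are considered here, and "the series" means these few. Any claim that something is new, unique, unknown or untested is made for them only; others in the source may bear on it.

In a toxicity assay on MT4 cells (Homo sapiens) for cytotoxicity, read by MTT assay, with a stated time of 7 days (on this read-out lower numbers stand for higher toxicity in this test and higher numbers for lower toxicity in this test), compound 1 `Cc1cc(C)cc(S(=O)(=O)c2c(C(=O)NC3CC4(CCN(Cc5n[nH]c(=O)n5C)C4)C3)[nH]c3ccc(Cl)cc23)c1` reaches only a limit of the assay, > 214000 nM.
In this assay compound 2 `Cc1cc(C)cc(S(=O)(=O)c2c(C(=O)NC3CC4(CCN(Cc5n[nH]c(=O)n5C)CC4)C3)[nH]c3ccc(Cl)cc23)c1` gives 178000 nM.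
In this assay compound 3 `Cc1cc(C)cc(S(=O)(=O)c2c(C(=O)NC3CC4(C3)CN(C(=O)OC(C)(C)C)C4)[nH]c3ccc(Cl)cc23)c1` again reaches only a limit of the assay, > 224000 nM.

Among the measured compounds shown here, compound 2 stands on the only number reported in this assay; the other two entries are limits. Compound 1 sits at the limit of > 214000 nM in this assay, at which 1 of the 3 values shown sits. Compound 3 sits at the limit of > 224000 nM in this assay, at which 1 of the 3 values shown sits. For the measured compounds named here, all three are therefore at or close to the top of the concentration range tested, and no step between measured compounds that differ in one place is available.

Compound 4 `Cc1cc(C)cc(S(=O)(=O)c2c(C(=O)NC3CC4(CCN(S(C)(=O)=O)CC4)C3)[nH]c3ccc(Cl)cc23)c1` is not yet measured. It differs from compound 2 by a group of 4 heavy atoms (1 carbon, 2 oxygen, 1 sulfur; no ring) in place of a group of 8 heavy atoms (4 carbon, 3 nitrogen, 1 oxygen; one five-membered aromatic ring with 3 hetero atoms), on an amine nitrogen in a ring. Going by the values given here, with no comparable step in hand, the expectation for this assay is no change beyond the scatter, in either direction. Compound 4 is expected to give 200000 nM, with a range from 100000 nM to 400000 nM. That estimate means an expected step of a 1.1-fold higher number from compound 2 to compound 4 (0.05 log units; within the scatter), which is within the scatter, and a fair chance that only a limit is reported.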

Compound 4, half-maximal cytotoxic concentration: > 221000 nM
Compound 4 was reported as a limit; the forecaster's own chance of this, stated with the estimate: 55%; at least 1.1-fold (0.04 log units) between middle value and limit.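

On the amine nitrogen of the six-membered ring, methylsulfonyl in place of the group of 8 heavy atoms gives an at least 1.2-fold higher number from compound 2 to compound 4 (0.09 log units; that floor lies within the scatter) in this assay. Among the compounds shown here, this is the first step that can be read at this position, and it shows that a compound without the five-membered aromatic ring also yields no measured toxicity value in this assay. Compound 4 is reported only as a limit of the assay: the limit of > 221000 nM in this assay, at which 1 of the 4 values shown sits.

Going by these compounds, how far the true value of compound 4 lies from that of compound 2 stays open, since only a floor for the step is known. Also open, on these data alone, is whether a different group on this nitrogen, such as a free amine, an acetyl group or a longer alkyl chain, would give a number clearly apart from that of compound 2.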